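From ethoxymethyl to isopropoxymethyl in a cell assay

A few compounds are considered here, and "the series" means these few. Any claim that something is new, unique, unknown or untested is made for them only; others in the source may bear on it.

- Compound 1 `Oc1c(CN2CCCCC2)ccc2cccnc12`: 5210 nM; 5130 nM (2 entries)
- Compound 2 `CCOCc1cc(CN2CCCCC2)c(O)c2ncccc12`: 8710 nM
- Compound 3 `CC(C)OCc1cc(CN2CCCCC2)c(O)c2ncccc12`: not yet measured

All of these values come from a functional assay on MES-SA cells (Homo sapiens) for inhibition, with a stated time of 72 h; a higher number here means a weaker inhibitor, a lower number a stronger inhibitor. In this assay, compound 2 has one number, 8710 nM, and one further entry that gives no single number. For the measured compounds named here, its only measured neighbour is compound 1, whose repeat entries agree well: the several entries of compound 1 in this assay, 5210 nM; 5130 nM (2 entries). The values of compound 1 and compound 2 lie within the usual scatter of each other.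

Compound 3 differs from compound 2 in one place: methyl in place of hydrogen on a saturated chain carbon bound to an oxygen on a saturated carbon and a saturated chain carbon. In other words, the ethoxymethyl group becomes isopropoxymethyl, with methyl in place of hydrogen on a saturated chain carbon bound to an oxygen. Going by the values given here, no pair of measured compounds shows what a change of this kind does in this assay, so no clear direction can be expected. The estimate therefore stays close to compound 2 at 8710 nM, with a wide range. The expected size of the step of a 1.1-fold lower number from compound 2 to compound 3 (0.04 log units; within the scatter) does not go beyond the scatter. For compound 3 the estimated value is 8000 nM, with an expected range of 3500 nM to 18000 nM.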

Compound 3, half-maximal inhibitory concentration: 6030 nM
The estimate for compound 3 lay 1.3-fold (0.12 log units) above the measured number, within the range that was stated.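

In this assay, for the compounds shown here, the change from ethoxymethyl to isopropoxymethyl now has a measured result, a 1.4-fold lower number from compound 2 to compound 3 (0.16 log units; within the scatter), and this is the first pair of compounds to differ in one place. A methyl group in place of hydrogen on this saturated chain carbon bound to an oxygen therefore leaves the inhibition of these cells indistinguishable from that of compound 2, so this part of the chain accepts one extra carbon with no effect that the assay can resolve. This is a single pair, and the step has to be judged against how closely repeat entries can agree, as seen for compound 1: the several entries of compound 1 in this assay, 5210 nM; 5130 nM (2 entries)

The compounds shown do not reveal how much larger the group on this oxygen can become before the number moves beyond the scatter, and a longer chain such as n-butyl or a bulkier group such as tert-butyl would test this. They also leave open whether a different kind of group in place of the ethyl, such as an amine or a carboxylic acid, would change the inhibition in either direction.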